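Chloro on the dihydroindole ring of compound 2

The compounds below may be only part of what the source reports. "The series", "measured", "known", "first", "only" and "open" are said of these compounds alone.

In an assay on isolated protein for inhibition of cathepsin S (Homo sapiens) (on this read-out lower numbers stand for stronger inhibition and higher numbers for weaker inhibition), compound 1 `Cc1cccc(C(=O)N[C@@H](CC(C)C)C(=O)NCCNc2ccc(F)cc2)c1` gives 563 nM. Among the compounds with values here, compound 2 `Cc1cccc(C(=O)N[C@@H](CC(C)C)C(=O)NCCN2CCc3ccccc32)c1` gives 230 nM in this assay, the lowest of the two numbers so far; the only measured step, a 2.4-fold lower number from compound 1 to compound 2 (0.39 log units; beyond the scatter), puts 2,3-dihydro-1H-indol-1-yl in place of (4-fluorophenyl)amino. Compound 3 `Cc1cccc(C(=O)N[C@@H](CC(C)C)C(=O)NCCN2CCc3cc(Cl)ccc32)c1` differs from compound 2 by chloro in place of hydrogen on an aromatic carbon, so that 2,3-dihydro-1H-indol-1-yl becomes 5-chloro-2,3-dihydro-1H-indol-1-yl. Within the data shown here, no measured step touches a substituent on this aromatic ring; the one step recorded concerns another part of the molecule and offers no direct guide to a chloro group here. A small shift in this assay is therefore expected, with a move to a lower number seen as somewhat more likely than a rise, though either could stay within the scatter. For compound 3 the step of a 1.5-fold lower number from compound 2 to compound 3 (0.19 log units; within the scatter) is estimated. Compound 3 is accordingly expected to give about 150 nM in this assay, within a range from 50 nM to 500 nM.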

Compound 3, inhibition constant: 196 nM
Estimate against measurement, compound 3: 1.3-fold (0.12 log units) below, and the stated range covers the measured number.
By their numbers in this assay, from the lowest: compounds 3 and 2 (each within the scatter of the next); then compound 1.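

In this assay, chloro in place of hydrogen on this aromatic carbon gives a 1.2-fold lower number from compound 2 to compound 3 (0.07 log units; within the scatter), so a single chlorine atom at this position of the 2,3-dihydro-1H-indol-1-yl group leaves the read-out within the scatter. The gain over the (4-fluorophenyl)amino group also survives the substitution, with the 5-chloro-2,3-dihydro-1H-indol-1-yl group giving a 2.9-fold lower number from compound 1 to compound 3 (0.46 log units; beyond the scatter). Nothing at hand explains either step.

As far as these compounds go, whether a different group on this aromatic carbon, such as methoxy, an amine or a carboxylic acid, would move the number beyond the scatter remains open. Also open, from the compounds shown here alone, is whether chloro on the other carbons of this aromatic ring would behave as it does here, and whether fluoro at this position would match chloro.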